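Transfer of a methoxy step to a second core

The source may hold more compounds than are shown below. What is called first, only, known or untested is meant among the compounds shown, and "the series" means these compounds.

Compound 1 `N#Cc1cc2[nH]c(-c3ccccc3)c(Cl)c2cc1C#N` is the parent of one pair; in an assay on isolated protein for inhibition of Amine oxidase [flavin-containing] B (Homo sapiens), read by fluorescence (a higher number here means a weaker inhibitor, a lower number a stronger inhibitor), compound 1 gives 144 nM. Compound 2 `COc1ccc(-c2[nH]c3cc(C#N)c(C#N)cc3c2Cl)cc1` carries methoxy in place of hydrogen on an aromatic carbon and in this assay compound 2 gives 20 nM. The step is a 7.2-fold lower number from compound 1 to compound 2 (0.86 log units; beyond the scatter).

Compound 3 `N#Cc1cc2c(Br)c(-c3ccccc3)n(O)c2cc1C#N` rests on a second core; the difference between the two cores is not broken down here. In this assay compound 3 gives 11900 nM, the highest of the three numbers measured, well apart from compound 1 and further from compound 2.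

Compound 4 `COc1ccc(-c2c(Br)c3cc(C#N)c(C#N)cc3n2O)cc1` has not been measured. It carries methoxy in place of hydrogen on an aromatic carbon, the same kind of change as from compound 1 to compound 2, at a place described in the same words. The expectation for compound 4 rests on that single earlier step, read once on a different core, so the transfer is uncertain. The step from compound 3 to compound 4 is expected to be a 6.0-fold lower number from compound 3 to compound 4 (0.77 log units; beyond the scatter), close in size to the earlier one. Compound 4 is therefore estimated at 2000 nM, within 600 nM to 7000 nM.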

Compound 4, half-maximal inhibitory concentration: 1520 nM
For compound 4 the middle estimate is 1.3-fold (0.12 log units) above the measured one, and the stated range covers the measured number.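

In this assay, methoxy in place of hydrogen on an aromatic carbon gives a 7.8-fold lower number from compound 3 to compound 4 (0.89 log units; beyond the scatter), and this step matches the one seen on the core of compound 1: the same change on two cores in this assay, a 7.2-fold lower number (0.86 log units; beyond the scatter) from compound 1 to compound 2 and a 7.8-fold lower number (0.89 log units; beyond the scatter) from compound 3 to compound 4, 1.1-fold (0.04 log units) apart, within the scatter of two such steps. On these two pairs, the change therefore carries from one core to the other with its direction and size kept. Going by these compounds alone, this rests on only two pairs in a single assay, so it does not show that the step is independent of the core in general, and it does not separate what the difference between the two cores itself contributes.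

The compounds shown leave open whether a longer chain such as ethoxy, a hydroxyl or an amine at the same place would also give matching steps on both cores. They also leave open whether methoxy elsewhere on this ring, or on a third core, would behave in the same way.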